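The source may report more compounds than this note shows. Statements on the series, on what has been measured and on what is new or still open speak of the compounds shown alone.

Working notes on the series. In a functional assay on MDA-MB-231 cells (Homo sapiens) for inhibition, read by WST assay, with a stated time of 48 h (a lower number here means a stronger inhibitor of growth, a higher number a weaker inhibitor of growth), compound 1 `CC/C=C\C/C=C\C/C=C\C/C=C\C/C=C\C/C=C\CCC(=O)Nc1ccccc1C(C)C` gives 8500 nM and compound 3 `CC/C=C\C/C=C\C/C=C\C/C=C\C/C=C\C/C=C\CCC(=O)Oc1ccccc1C(C)C` gives 12100 nM, so these two numbers stand together: a 1.4-fold higher number from compound 1 to compound 3 (0.15 log units; within the scatter). Compound 2 `CC/C=C\C/C=C\C/C=C\C/C=C\C/C=C\C/C=C\CCC(=O)Oc1ccccc1` returns only a limit, > 25000 nM. Compound 4 `CC/C=C\C/C=C\C/C=C\C/C=C\C/C=C\C/C=C\CCC(=O)Nc1c(C(C)C)cccc1C(C)C` changes 2-isopropylphenyl to 2,6-diisopropylphenyl: isopropyl in place of hydrogen on an aromatic carbon. One measured step makes the same exchange, isopropyl in place of hydrogen on an aromatic carbon: an at least 2.0-fold lower number from compound 2 to compound 3 (0.31 log units; beyond the scatter). Within the data shown here, that step starts from a limit and adds a first isopropyl, whereas no measured step adds a second. In this assay, only a small move toward a lower number is therefore expected, and it may stay within the scatter: a 1.4-fold lower number from compound 1 to compound 4 (0.15 log units; within the scatter). For compound 4 the estimate is 6000 nM, with an expected range of 2500 nM to 14000 nM.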

Compound 4, concentration for total growth inhibition: 5500 nM
The estimate for compound 4 lay 1.1-fold (0.04 log units) above the measured number; the measured number falls inside the stated range.
By their numbers in this assay, from the lowest: compounds 4, 1 and 3 (each within the scatter of the next, the first and the last beyond it). At a limit, above all of these: compound 2.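

The position ortho to a large group takes a second isopropyl with no shift beyond the scatter in this assay: a 1.5-fold lower number from compound 1 to compound 4 (0.19 log units; within the scatter). This is the first measured case of the exchange that starts from a number on both sides, and it can be set only loosely against the other case: the same change on two cores in this assay, an at least 2.0-fold lower number (0.31 log units; beyond the scatter) from compound 2 to compound 3 and a 1.5-fold lower number (0.19 log units; within the scatter) from compound 1 to compound 4; the limit leaves it open whether they differ

The compounds shown leave open how a smaller group such as methyl or a larger one such as tert-butyl would read at this position. They also leave open whether a second isopropyl on the ester of compound 3 would behave as it does on the amide.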